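The compounds below may be only part of what the source reports. "The series", "measured", "known", "first", "only" and "open" are said of these compounds alone.

Measured so far:
compound 1 `O=C(O)C12CC(CN3CCC[C@H](O[C@H](CO)c4cc(Cl)cc(Cl)c4)[C@@H]3c3ccccc3)(C1)C2` – > 200000 nM
compound 2 `COC(=O)c1ccc(CN2CCC[C@H](O[C@H](CO)c3cc(Cl)cc(Cl)c3)[C@@H]2c2ccccc2)c(C)c1` – > 200000 nM
compound 3 `Cc1cc(C(=O)O)ccc1C(C)N1CCC[C@H](O[C@H](CO)c2cc(Cl)cc(Cl)c2)[C@@H]1c1ccccc1` – "nd" (no result reported)

Compound 3 has no number in an assay on isolated protein for activation of cGMP-dependent protein kinase 1 (Homo sapiens), read by ADP-Glo, with stated times of 30 min and 2 h; a lower number here means that less compound is needed, a higher number that more compound is needed for the effect; its entry reads "nd" (no result reported) and nothing further. The two measured neighbours each give only a limit of the assay. Compound 1 returns a limit, > 200000 nM. Compound 2 likewise returns a limit, > 200000 nM. The step that the two limits leave unreadable from compound 1 to compound 2 is therefore unreadable, as the limit of > 200000 nM in this assay, at which 2 of the 3 values shown sit, shows. Compound 4 `O=C(O)c1ccc(CN2CCC[C@H](O[C@H](CO)c3cc(Cl)cc(Cl)c3)[C@@H]2c2ccccc2)cc1` carries the change (a group of 10 heavy atoms (8 carbon, 2 oxygen; one six-membered aromatic ring of carbon only) in place of a group of 12 heavy atoms (10 carbon, 2 oxygen; one six-membered aromatic ring of carbon only), on an amine nitrogen in a ring). For the measured compounds named here, no measured step covers this exchange, and nothing measured has yet come down from the limit, so no direction can be read. Compound 4 is expected to sit near that same limit, estimated at 200000 nM with a range of 50000 nM to 500000 nM.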

Compound 4, half-maximal effective concentration: 77000 nM
The estimate for compound 4 lay 2.6-fold (0.41 log units) above the measured number; the measured number falls inside the stated range.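

In this assay, for the compounds shown here, compound 4 is the first to give a number rather than a limit, placing 4-carboxybenzyl on the amine nitrogen in a ring. The exchange reads as an at least 2.5-fold lower number from compound 2 to compound 4 (0.41 log units; beyond the scatter) and as an at least 2.5-fold lower number from compound 1 to compound 4 (0.41 log units; beyond the scatter). Compound 1 and compound 2 each stand at a limit, and both steps are bounded on one side only: the limit of > 200000 nM in this assay, at which 2 of the 4 values shown sit.

The step from compound 2 changes the methyl ester and the methyl on the aromatic ring together, leaving their shares unseparated. As far as these compounds go, how an amide in place of the carboxylic acid, or a longer chain on the amine nitrogen, would read remains open.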